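The compounds below may be only part of what the source reports. "The series", "measured", "known", "first", "only" and "open" are said of these compounds alone.

The measured compounds:
compound 1, `Cc1nc(N)c2c(-c3ccco3)cn([C@@H]3O[C@H](CO)[C@@H](O)[C@H]3O)c2n1` — > 20000 nM
compound 2, `COc1nc(N)nc2c1c(-c1ccoc1)cn2[C@@H]1O[C@H](CO)[C@@H](O)[C@H]1O` — > 20000 nM
compound 3, `Cc1nc(N)c2c(-c3ccoc3)cn([C@@H]3O[C@H](CO)[C@@H](O)[C@H]3O)c2n1` — > 20000 nM

All three were tested in a functional assay on K562 cells (Homo sapiens), read by MTT assay, with a stated time of 72 h; a lower number here means a stronger inhibitor, a higher number a weaker inhibitor. Compound 1 gives only a limit of the assay there, > 20000 nM. Compound 3 likewise returns a limit and not a number, > 20000 nM. Compound 2 also gives only a limit, > 20000 nM. Among the measured compounds shown here, the single change from compound 3 to compound 1 is furan-2-yl in place of furan-3-yl on an aromatic carbon; the step it made, a step that the two limits leave unreadable from compound 3 to compound 1, cannot be sized, because both ends sit at the limit of > 20000 nM in this assay, at which 3 of the 3 values shown sit. Compound 2 and compound 3 differ in more than one place, and the difference between the two cores is not broken down here.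

Compound 4, `COc1nc(N)nc2c1c(-c1ccco1)cn2[C@@H]1O[C@H](CO)[C@@H](O)[C@H]1O`, has not yet been measured in this assay. It differs from compound 2 by furan-2-yl in place of furan-3-yl on an aromatic carbon, the same change as that from compound 3 to compound 1, at the same place. With both compounds 1 and 3 at the limit, that earlier pair gives no readable direction for the change. Compound 2 itself gives only a limit, > 20000 nM. On that basis the step from compound 2 to compound 4 is expected to be small, a step that the limit leaves unreadable from compound 2 to compound 4. Compound 4 is therefore expected to sit at about 25000 nM, most likely between 10000 nM and 60000 nM, and most probably again as a limit rather than a number.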

Compound 4, half-maximal inhibitory concentration: > 20000 nM
Compound 4: no number, only a limit; the forecaster's own chance of this, stated with the estimate: 85%; the middle value lies beyond the limit too.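

In this assay compound 4 gives only a limit, > 20000 nM. Compound 2 also gives only a limit, so no step can be read between compound 2 and compound 4, and the change from furan-3-yl to furan-2-yl remains unsized on this core as well: the limit of > 20000 nM in this assay, at which 4 of the 4 values shown sit. The compounds shown leave open how furan-2-yl and furan-3-yl compare in this assay, on either core.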